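Cyclohexyl for 4-methoxyphenyl on the piperazine of compound 1

The source may hold more compounds than are shown below. What is called first, only, known or untested is meant among the compounds shown, and "the series" means these compounds.

Compound 1 `COc1ccc(N2CCN(C(=S)SCc3ccc(C(=O)Nc4ccccc4N)cc3)CC2)cc1` and compound 2 `Nc1ccccc1NC(=O)c1ccc(CSC(=S)N(Cc2ccccc2)Cc2ccccc2)cc1` share a benzamide-dithiocarbamate core and differ in the amine that carries the thiocarbonyl. In a functional assay on HeLa cells (Homo sapiens) for antiproliferative activity, read by CCK-8 assay, with a stated time of 72 h, tested at 8 uM (on this read-out higher numbers stand for a stronger effect at the one concentration tested and lower numbers for a weaker effect), compound 1 gives 52.3%, the higher of the two numbers recorded. In this assay compound 2 gives 18.9%, a number well beyond the scatter below that of compound 1. Compound 3 `Nc1ccccc1NC(=O)c1ccc(CSC(=S)N2CCN(C3CCCCC3)CC2)cc1` keeps the ring amine of compound 1 and changes only the group on it: cyclohexyl in place of 4-methoxyphenyl on an amine nitrogen in a ring. Among the measured compounds shown here, no measured pair isolates this change, so the step in this assay is judged from the position of compound 1 alone, and a modest downward move, within or just beyond the scatter, is what is expected here. Compound 3 is therefore estimated to reach 44% in this assay, with a plausible range from 22% to 66%. This estimate means an expected step of a number 8.3 percentage points lower from compound 1 to compound 3 (within the scatter).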

Compound 3, a percentage reported as inhibition, at one concentration (the size of the read-out at that concentration, not a potency): 76.1%
Compound 3: middle estimate off by 32.1 percentage points, on the low side; the whole stated range lies below it.
By their numbers in this assay, from the lowest: compound 2; then compound 1; then compound 3.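

Moving from an aromatic to a non-aromatic ring on this amine nitrogen gives a number 23.8 percentage points higher from compound 1 to compound 3 (beyond the scatter) in this assay, so the group at this position has a clear bearing on the read-out. The 4-methoxyphenyl group, with its aromatic ring and its oxygen, is therefore not required for the effect at the one concentration tested, and cyclohexyl serves better here. Nothing measured on these compounds gives a reason for this step. 

Among the compounds shown here, with only this one pair, it remains open whether the step belongs to the loss of the methoxy group, to the loss of aromaticity or to the cyclohexyl ring itself. An unsubstituted phenyl, a cyclopentyl ring or an open chain such as n-butyl on the same nitrogen would help to separate these possibilities.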